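Series notes: replacing the nitrile of compound 2

The source may report more compounds than this note shows. Statements on the series, on what has been measured and on what is new or still open speak of the compounds shown alone.

Compound 2 `N#Cc1ccccc1COc1ccccc1C(=O)Nc1cccnc1` stands highest of the two numbers: in an assay on lysate for inhibition of phosphatidylcholine:ceramide cholinephosphotransferase 2 (Homo sapiens), read by HPLC, with stated times of 30 min and 2 h (on this read-out lower numbers stand for stronger inhibition and higher numbers for weaker inhibition), compound 2 gives 31800 nM, while compound 1 `O=C(Nc1cccnc1)c1ccccc1OCc1ccccc1Cl` gives 1100 nM. For the measured compounds named here, the one step that bears here is a 29-fold higher number from compound 1 to compound 2 (1.46 log units; beyond the scatter). Compound 3 `O=C(Nc1cccnc1)c1ccccc1OCc1ccccc1OCCCCCl` carries 4-chlorobutoxy in place of cyano on an aromatic carbon, so the nitrile that marked that step leaves and a halogen-bearing chain enters. Going by the values given here, removing the nitrile is expected to bring the number down, though no compound shows the entering group, so the expected step of a 9.1-fold lower number from compound 2 to compound 3 (0.96 log units; beyond the scatter) is set short of a full return to compound 1. For compound 3 the estimate is 3500 nM, with a range from 800 nM to 15000 nM.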

Compound 3, half-maximal inhibitory concentration: 1300 nM
Estimate against measurement, compound 3: 2.7-fold (0.43 log units) above, within the range that was stated.
By their numbers in this assay, from the lowest: compounds 1 and 3 (each within the scatter of the next); then compound 2.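

On this aromatic carbon, ortho to a large group, the weak number of compound 2 does not extend to every replacement of chloro: in this assay there is a 24-fold lower number from compound 2 to compound 3 (1.39 log units; beyond the scatter) on going to 4-chlorobutoxy. Chloro and the far larger 4-chlorobutoxy cannot be told apart here, with a 1.2-fold higher number from compound 1 to compound 3 (0.07 log units; within the scatter) as the step between them. No evidence at hand bears on this result.

Open, on these data alone, is whether the terminal chlorine of the chain matters, which a plain butoxy chain would test. Also open, as far as these compounds go, is how an amine or a carboxylic acid at the chain end would read.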